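Solubility of a tert-butyl analogue of compound 2

The compounds below may be only part of what the source reports. "The series", "measured", "known", "first", "only" and "open" are said of these compounds alone.

Three ureas sharing one core have been measured in a physicochemical assay for solubility, at pH 7.4; on this read-out lower numbers stand for lower solubility and higher numbers for higher solubility. Compound 1 `Cc1cc(NC(=O)Nc2cccc(Cl)c2)c2ccccc2n1` gives 800 nM. Compound 2 `Cc1cc(NC(=O)Nc2ccc(F)cc2)c2ccccc2n1` gives 3700 nM, the highest of the three numbers; compound 3 `Cc1cc(NC(=O)Nc2ccc(F)c(F)c2)c2ccccc2n1` gives 500 nM. The step of a 4.6-fold higher number from compound 1 to compound 2 (0.67 log units; beyond the scatter) and the step of a 7.4-fold lower number from compound 2 to compound 3 (0.87 log units; beyond the scatter) both lie beyond the scatter, so compound 2 stands clearly above its two neighbours.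

Compound 4 `Cc1cc(NC(=O)Nc2ccc(C(C)(C)C)cc2)c2ccccc2n1` is the next member and has not yet been measured in this assay. It differs from compound 2 in one place: tert-butyl in place of fluoro on an aromatic carbon. Within the data shown here, no measured step carries a tert-butyl, so the bearing of the earlier steps is indirect. The step of a 7.4-fold lower number from compound 2 to compound 3 (0.87 log units; beyond the scatter) shows that adding one heavy atom to the ring bearing the fluoro already moves the number well beyond the scatter, and the step of a 4.6-fold higher number from compound 1 to compound 2 (0.67 log units; beyond the scatter) shows that swapping one halogen for another on that ring does the same. A group of four carbon atoms entering para to a large group is a larger change than either, so a drop is expected, of a size at least like those steps.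

Compound 4 is therefore estimated at 400 nM, between 100 nM and 1500 nM, the expected step being a 9.3-fold lower number from compound 2 to compound 4 (0.97 log units; beyond the scatter).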

Compound 4, solubility: 6200 nM
Beside the measured number, compound 4's estimate is 16-fold (1.19 log units) below it, outside the stated range (above it).
By their numbers in this assay, from the lowest: compounds 3 and 1 (each within the scatter of the next); then compounds 2 and 4 (each within the scatter of the next).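

Read in this assay, the step of a 1.7-fold higher number from compound 2 to compound 4 (0.22 log units; within the scatter) shows that this place, an aromatic carbon of a six-membered aromatic ring of carbon only, para to a large group, can take tert-butyl in place of fluoro with no change in the number beyond the scatter, even though four carbon atoms enter where one fluorine leaves. The earlier steps on this ring did not show this: both a 4.6-fold higher number from compound 1 to compound 2 (0.67 log units; beyond the scatter) and a 7.4-fold lower number from compound 2 to compound 3 (0.87 log units; beyond the scatter) lie beyond the scatter, so among the compounds shown, the count of heavy atoms entering does not go with the size of the step, and compound 4 is the one that goes against any reading in which a larger change gives a larger step. Nothing in the material offers an explanation for this result.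

On these data alone, whether a group of another kind at the same place, such as an amine, a carboxylic acid or a longer chain, would also stay within the scatter of compound 2 remains open. As far as these compounds go, it is also open whether tert-butyl would behave in the same way on a urea with a different core.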